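Adding a nitrile to the phenoxy group: expected tolerance

The compounds below may be only part of what the source reports. "The series", "measured", "known", "first", "only" and "open" are said of these compounds alone.

Compound 3, with structure `COc1ccccc1Oc1nc(Nc2ccc(C#N)cc2)nc2ccccc12`, is tested in an ADME assay on MT4 cells (Homo sapiens) for cytotoxicity, read by MTT assay, with a stated time of 4 days (a lower number here means that less compound is tolerated, a higher number that more compound is tolerated), where compound 3 gives 150000 nM. Among the three compounds measured, compound 3 stands second highest; its nearest neighbour is compound 1, of structure `COc1cc(C#N)cc(OC)c1Oc1nc(Nc2ccc(C#N)cc2)nc2ccccc12`, which in this assay gives 194000 nM, a value within the scatter of that of compound 3. Among the compounds with values here, the furthest is compound 2, of structure `Cc1cccc(C)c1Oc1nc(Nc2ccc(C#N)cc2)nc2ccccc12`, which in this assay gives 35000 nM; the step of a 4.3-fold higher number from compound 2 to compound 3 (0.63 log units; beyond the scatter) is the only one between measured compounds that differ in one place.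

Compound 4, of structure `COc1cc(C#N)ccc1Oc1nc(Nc2ccc(C#N)cc2)nc2ccccc12`, has not yet been measured in this assay. It differs from compound 3 by cyano in place of hydrogen on an aromatic carbon. Within the data shown here, no measured step follows this exact change. The step from compound 2 to compound 3 concerns a different exchange and does not bear on it. What the numbers show is that compound 1, which carries a cyano group on the phenoxy ring together with two methoxy groups, and compound 3 lie within the scatter of each other. On this basis one expects the step of a 1.1-fold higher number from compound 3 to compound 4 (0.05 log units; within the scatter) to stay within the usual scatter. Compound 4 is therefore estimated at 170000 nM in this assay, with a range from 70000 nM to 400000 nM.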

Compound 4, half-maximal cytotoxic concentration: >= 140000 nM
Compound 4: no number, only a limit (the forecaster's own chance of this, stated with the estimate: 15%); the middle value does not contradict the limit.
By their numbers in this assay, from the lowest: compound 2; then compounds 3 and 1 (each within the scatter of the next).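

In this assay compound 4 gives only a limit of the assay and not a number: the limit of >= 140000 nM in this assay, at which 1 of the 4 values shown sits.

The steps from compound 3 and from compound 1 to compound 4 cannot be read, so cyano in place of hydrogen on this aromatic carbon, para to a large group and meta to a methoxy group, still has no measured size. Within the data shown here, the limit does tell something that the earlier compounds could not: with cyano at this place and a single methoxy group on the ring, the 4-cyano-2-methoxyphenyl group in place of 2,6-dimethylphenyl gives an at least 4.0-fold higher number from compound 2 to compound 4 (0.60 log units; beyond the scatter), so this compound stays clearly apart from the low end of the set.

As far as these compounds go, it remains open how far the true number of compound 4 lies from that of compound 3, and whether an amine or a carboxylic acid in place of the cyano on this aromatic carbon would leave the number where it stands. Also open, from the compounds shown here alone, is what the same cyano would do on the 2,6-dimethylphenyl group of compound 2.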